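A few compounds are considered here, and "the series" means these few. Any claim that something is new, unique, unknown or untested is made for them only; others in the source may bear on it.

Working notes on the series. In an assay on HEK293 cells for displacement of a labelled ligand from Melanocortin receptor 4 (Homo sapiens) (a lower number here means a stronger inhibitor, a higher number a weaker inhibitor), compound 2, `CC(C)C[C@H](N)c1cc(C(F)(F)F)ccc1N1CCN(C(=O)CCc2ccccc2Cl)CC1`, gives 1700 nM, the highest of the two numbers at hand; the nearest is compound 1, `CCCCC(N)c1cc(C(F)(F)F)ccc1N1CCN(C(=O)CCc2ccc(Cl)cc2Cl)CC1`, which in this assay gives 190 nM, a gap that lies beyond the scatter. Compound 1 and compound 2 differ in more than one place, so those two values alone cannot be read as a single step.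

Compound 3, `COc1cccc(CCC(=O)N2CCN(c3ccc(C(F)(F)F)cc3[C@@H](N)CC(C)C)CC2)c1`, has not yet been measured in this assay. It differs from compound 2 by 3-methoxyphenyl in place of 2-chlorophenyl on a saturated chain carbon, two bonds along the chain from a carbonyl carbon. No measured pair in this set isolates that change, so there is nothing to lean on beyond the two numbers shown. The expectation is a modest step toward a weaker inhibitor, one that may not clear the scatter: a 1.5-fold higher number from compound 2 to compound 3 (0.17 log units; within the scatter). Compound 3 is accordingly estimated at 2500 nM in this assay, with a range from 800 nM to 8000 nM.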

Compound 3, inhibition constant: 4000 nM
Compound 3: middle estimate off by 1.6-fold (0.20 log units), on the low side; the range from low to high includes it.
By their numbers in this assay, from the lowest: compound 1; then compound 2; then compound 3.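

In this assay, among the compounds shown here, 3-methoxyphenyl in place of 2-chlorophenyl on a saturated chain carbon, two bonds along the chain from a carbonyl carbon, gives a 2.4-fold higher number from compound 2 to compound 3 (0.37 log units; beyond the scatter), the first change that can be read in one place. This position is therefore not indifferent to the aryl group it carries, at least for this one pair, and the exchange moves toward a weaker inhibitor. No measurement at hand bears on the origin of this step.

Going by these compounds, an unsubstituted phenyl at this place remains open, so the step cannot yet be divided between the loss of chlorine and the gain of methoxy. On these data alone, a longer chain between the carbonyl and the aromatic ring also remains open, as does whether this step holds on other side chains of the shared core.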